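From a sec-butyl amide to a benzamide

This account rests on a few compounds, and the source may have more. Where it says the series, first, only, none or still open, it means among the compounds named here.

In a functional assay on HT-29 cells (Homo sapiens) for antiproliferative activity, read by sulforhodamine B assay, with a stated time of 72 h (on this read-out lower numbers stand for stronger inhibition and higher numbers for weaker inhibition), the measured compounds read as follows:
compound 1 `CCCCCCCCc1ccc(CCC(CO)(CO)NC(=O)CCC)c2ccccc12` gives 26400 nM
compound 2 `CCCCCCCCc1ccc(CCC(CO)(CO)NC(=O)CCCCCCC)c2ccccc12` gives 22000 nM
compound 3 `CCCCCCCCc1ccc(CCC(CO)(CO)NC(=O)C(C)CC)c2ccccc12` gives 25600 nM

Compound 3 at 25600 nM stands within the scatter of both other compounds, so its place among the three carries no real order. The next compound, compound 4 `CCCCCCCCc1ccc(CCC(CO)(CO)NC(=O)c2ccccc2)c2ccccc12`, has phenyl in place of sec-butyl on a carbonyl carbon. The measured steps bearing on this change all alter the same carbonyl substituent (a 1.2-fold lower number from compound 1 to compound 2 (0.08 log units; within the scatter); a 1.0-fold lower number from compound 1 to compound 3 (0.01 log units; within the scatter); a 1.2-fold higher number from compound 2 to compound 3 (0.07 log units; within the scatter)) and each stays within the scatter. None of them places a ring there, so this precedent is only indirect. In this assay no step beyond the scatter is therefore expected, in either direction. The estimated step is a 1.2-fold lower number from compound 3 to compound 4 (0.07 log units; within the scatter) and would stay within the scatter. For compound 4 the estimated value is 22000 nM with an expected range from 12000 nM to 38000 nM on repeat measurement.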

Compound 4, half-maximal inhibitory concentration: 23000 nM
The estimate for compound 4 lay 1.0-fold (0.02 log units) below the measured number, within the range that was stated.
By their numbers in this assay, from the lowest: compounds 2, 4, 3 and 1 (each within the scatter of the next).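

In this assay the phenyl of compound 4 puts a ring on the carbonyl carbon, and the step stays within the scatter against sec-butyl (a 1.1-fold lower number from compound 3 to compound 4 (0.05 log units; within the scatter)), against heptyl (a 1.0-fold higher number from compound 2 to compound 4 (0.02 log units; within the scatter)) and against propyl (a 1.1-fold lower number from compound 1 to compound 4 (0.06 log units; within the scatter)). The earlier compounds shown here carried only open chains at this place, so the new point is that, across these four compounds, a six-membered aromatic ring of carbon only reads no differently from a straight or branched chain. Nothing at hand gives a reason for this result.

Every group shown here is made of carbon alone, so it remains open whether an amine or a carboxylic acid at this place would move the number beyond the scatter. The same question stands for a phenyl bearing a substituent, such as chlorophenyl or methoxyphenyl.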